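Fluoromethyl to trifluoromethyl: notes on compound 3

A few compounds are considered here, and "the series" means these few. Any claim that something is new, unique, unknown or untested is made for them only; others in the source may bear on it.

Going by the values given here, in an ADME assay on microsomes from liver (Homo sapiens) for metabolic stability, read by LC-MS, with a stated time of 15 min (a lower number here means that less of the compound is left, a higher number that more of the compound is left), compound 1 (`CCNC(=O)Nc1sc2ccccc2c1C(=O)N1CCN(C2CCN(C(=O)OC(C)C)CC2)CC1`) gives 3% and compound 2 (`CCNC(=O)Nc1sc2ccccc2c1C(=O)N1CCN(C2CCN(C(=O)OC(C)(C)CF)CC2)CC1`) gives 3% so compound 2 stands level with its only measured neighbour. Among the compounds with values here, that comparison is the single measured step bearing on the change ahead: no change at the digits printed from compound 1 to compound 2 (within the scatter) with fluoromethyl in place of hydrogen on a saturated chain carbon bound to an oxygen next to a carbonyl group and two saturated chain carbons.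

Compound 3 (`CCNC(=O)Nc1sc2ccccc2c1C(=O)N1CCN(C2CCN(C(=O)OC(C)(C)C(F)(F)F)CC2)CC1`) carries trifluoromethyl in place of fluoromethyl at that same place (trifluoromethyl in place of fluoromethyl on a saturated chain carbon bound to an oxygen next to a carbonyl group and two saturated chain carbons). Within the data shown here, no measured compound holds trifluoromethyl, so the precedent is thin. Resting on no change at the digits printed from compound 1 to compound 2 (within the scatter) as the sole guide, the expected step in this assay is a number 1 percentage points higher from compound 2 to compound 3 (within the scatter) with no expected shift beyond the scatter. Compound 3 is estimated at 4% (expected range 1% to 14%).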

Compound 3, percent of the compound remaining in the Homo sapiens assay: 5%
Estimate against measurement, compound 3: 1 percentage points below; the range from low to high includes it.
By their numbers in the Homo sapiens assay, from the lowest: compounds 1, 2 and 3 (each within the scatter of the next).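

In the Homo sapiens assay the step on to trifluoromethyl gives a number 2 percentage points higher from compound 2 to compound 3 (within the scatter) and the full change from hydrogen gives a number 2 percentage points higher from compound 1 to compound 3 (within the scatter) so neither degree of fluorination shown here moves the number beyond the scatter. In a physicochemical assay, read by HPLC, with a stated time of 3 h, at pH 1.2 (on this read-out lower numbers stand for a less stable compound and higher numbers for a more stable compound), the same change gives a number 2 percentage points higher from compound 2 to compound 3 (within the scatter) with compound 2 (98%) and compound 3 (100%) both close to fully retained, so this read-out also separates neither group from the other. No measurement at hand explains either result.

As far as these compounds go, whether the number in the Homo sapiens assay responds to this place at all remains open, with all three compounds still close together at the bottom of the scale. A longer chain or an amine at this place, or a change elsewhere on the shared core, could show whether any part of the molecule lifts it beyond the scatter.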